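Swapping the Aryl Group on the Amide Nitrogen

The source may report more compounds than this note shows. Statements on the series, on what has been measured and on what is new or still open speak of the compounds shown alone.

Compound 2 `O=C(CN1CCC(c2cccc[n+]2[O-])CC1)Nc1cccc(Cl)c1Cl` gives 66% in a functional assay on HEK293 cells for agonist activity at D(4) dopamine receptor (Homo sapiens), read by FLIPR; a higher number here means a larger maximal response, a lower number a smaller maximal response. Among the measured compounds shown here, this is the higher of the two numbers measured so far, though its gap to compound 1 `CCc1cccc(NC(=O)CN2CCC(c3cccc[n+]3[O-])CC2)c1`, which gives 62% in this assay, lies within the scatter. Compound 3 `O=C(CN1CCC(c2cccc[n+]2[O-])CC1)Nc1ccc(F)cc1` awaits measurement. It differs from compound 2 in one place: 4-fluorophenyl in place of 2,3-dichlorophenyl on an amide-type nitrogen. For the measured compounds named here, the only measured step that bears on this change is the one that also exchanges the aryl group on the amide-type nitrogen, a number 4 percentage points higher from compound 1 to compound 2 (within the scatter). That step moved the maximal response by almost nothing, so a comparable exchange in compound 3 is expected to give a step of a number 4 percentage points lower from compound 2 to compound 3 (within the scatter), with no direction beyond the scatter. Compound 3 is accordingly estimated at 62%, with a range from 48% to 76%.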

Compound 3, largest response reached (reported as efficacy), in percent of the reference or control that the assay uses: 71%
Compound 3: the middle estimate sits 9 percentage points below what was measured, and the stated range covers the measured number.
By their numbers in this assay, from the lowest: compounds 1, 2 and 3 (each within the scatter of the next).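

On the amide-type nitrogen, a third aryl group repeats what the first two showed: in this assay the exchange of 2,3-dichlorophenyl for 4-fluorophenyl gives a number 5 percentage points higher from compound 2 to compound 3 (within the scatter) and the exchange of 3-ethylphenyl for 4-fluorophenyl gives a number 9 percentage points higher from compound 1 to compound 3 (within the scatter) as well. Among these three compounds, then, the maximal response cannot be told apart, even though the substituents on the phenyl ring differ in kind and in where they sit. Nothing measured here gives a reason for this sameness.

On these data alone, all three groups are substituted phenyl rings, so it remains open whether the response stays in this range with a group of another type on the nitrogen, such as cyclohexyl or benzyl. As far as these compounds go, it is equally open what a phenyl ring carrying an amine or a carboxylic acid would do.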